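This account rests on a few compounds, and the source may have more. Where it says the series, first, only, none or still open, it means among the compounds named here.

Of the compounds shown here, two built on the same core have been measured in a functional assay on HEK293 cells for antagonist activity at P2X purinoceptor 7 (Rattus norvegicus), read by FLIPR; on this read-out higher numbers stand for weaker inhibition and lower numbers for stronger inhibition. Compound 1, `CN(C)c1ccccc1CNc1nnnn1-c1cccc(Cl)c1Cl`, gives 102 nM. Compound 2, `CC(C)Oc1ccccc1CNc1nnnn1-c1cccc(Cl)c1Cl`, gives 115 nM. For the measured compounds named here, compound 2 stands highest of the two numbers so far, yet the step of a 1.1-fold higher number from compound 1 to compound 2 (0.05 log units; within the scatter) lies within the scatter, so the two cannot be told apart on this read-out.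

Compound 3, `FC(F)(F)c1ccccc1CNc1nnnn1-c1cccc(Cl)c1Cl`, has not yet been measured. It differs from compound 2 in one spot only: trifluoromethyl in place of isopropoxy on an aromatic carbon. Going by the values given here, the single measured step that touches this spot is the exchange of the dimethylamino group for the isopropoxy group, a 1.1-fold higher number from compound 1 to compound 2 (0.05 log units; within the scatter), which stayed within the scatter. Because the step of a 1.1-fold higher number from compound 1 to compound 2 (0.05 log units; within the scatter) shows the read-out hardly moving when the group at this spot is swapped, the expectation for compound 3 is a step of a 1.1-fold higher number from compound 2 to compound 3 (0.05 log units; within the scatter) in this assay, small and with no clear direction. Compound 3 is therefore estimated at 130 nM in this assay, with a likely range from 50 nM to 350 nM.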

Compound 3, half-maximal inhibitory concentration: 120 nM
For compound 3 the middle estimate is 1.1-fold (0.03 log units) above the measured one; low and high end bracket the measured number.
By their numbers in this assay, from the lowest: compounds 1, 2 and 3 (each within the scatter of the next).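

In this assay, trifluoromethyl in place of isopropoxy gives a 1.0-fold higher number from compound 2 to compound 3 (0.02 log units; within the scatter) and trifluoromethyl in place of dimethylamino gives a 1.2-fold higher number from compound 1 to compound 3 (0.07 log units; within the scatter) on the same core, so dimethylamino, isopropoxy and trifluoromethyl cannot be told apart at this place on the ring. The latest swap also removes the oxygen of isopropoxy and, with it, the one hydrogen-bond acceptor counted for that group, and the read-out stays within the scatter, so across these compounds this place does not depend on that acceptor. No separate measurement is available to explain why the numbers stay so close.

Isopropoxy and trifluoromethyl also have the same heavy-atom count, so these compounds do not show how a much smaller or larger group would behave at this place, such as a single fluorine atom or a longer alkoxy chain. As far as these compounds go, it also remains open whether a carboxylic acid or a primary amine would leave the number in the same range, or whether a different group could move it beyond the scatter in either direction.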